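Swapping a methoxyphenyl for naphthyl on a pyrazoline-type core

The source may report more compounds than this note shows. Statements on the series, on what has been measured and on what is new or still open speak of the compounds shown alone.

Compound 2 `COc1ccc(C2=NN(C3=NC(=O)/C(=C4\C(=O)Nc5ccccc54)S3)C(c3ccc(OC)cc3)C2)cc1` gives the highest number of the two measured in a functional assay on cells (Cancer cell lines, Homo sapiens) for cytotoxicity, read by sulforhodamine B assay, with a stated time of 48 h (on this read-out higher numbers stand for weaker inhibition of growth and lower numbers for stronger inhibition of growth), at 99600 nM. Its closest neighbour, compound 1 `COc1ccc(C2CC(c3ccccc3)=NN2C2=NC(=O)/C(=C3\C(=O)Nc4ccccc43)S2)cc1`, gives 4580 nM in this assay, and the step of a 22-fold higher number from compound 1 to compound 2 (1.34 log units; beyond the scatter) came from a methoxy in place of hydrogen on an aromatic carbon. Compound 3 `COc1ccc(C2CC(c3ccc4ccccc4c3)=NN2C2=NC(=O)/C(=C3\C(=O)Nc4ccccc43)S2)cc1` differs from compound 2 by naphthalen-2-yl in place of 4-methoxyphenyl on a carbon with a double bond to nitrogen. For the measured compounds named here, that change removes the methoxy-bearing ring altogether, so a move back toward compound 1 is expected; a naphthalen-2-yl group has no measured precedent here, so the expected step of a 12-fold lower number from compound 2 to compound 3 (1.10 log units; beyond the scatter) carries wide uncertainty. Compound 3 is estimated at 8000 nM, between 1500 nM and 45000 nM.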

Compound 3, concentration for total growth inhibition: 32800 nM
For compound 3 the middle estimate is 4.1-fold (0.61 log units) below the measured one; measured number inside the range.
By their numbers in this assay, from the lowest: compound 1; then compound 3; then compound 2.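

At this carbon with a double bond to nitrogen, this assay gives a mixed picture: the change to naphthalen-2-yl produces a 3.0-fold lower number from compound 2 to compound 3 (0.48 log units; beyond the scatter), but the comparison with phenyl gives a 7.2-fold higher number from compound 1 to compound 3 (0.86 log units; beyond the scatter). Size alone does not set the order, since compound 2, with one aromatic ring, gives a higher number than compound 3, with two. Nothing available here explains this order.

Still open, going by these compounds, is how a small group such as methyl, or a phenyl ring carrying an amine or a carboxylic acid, would behave at this carbon.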